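Ring-size change at the anilino substituent of the amide series

A few compounds are considered here, and "the series" means these few. Any claim that something is new, unique, unknown or untested is made for them only; others in the source may bear on it.

Compound 1 `C=CCNc1ccc(C(=O)N2CCCCc3ccccc32)c(Cl)c1` gives 5.9 nM in an assay on HeLa cells for binding affinity to Vasopressin V2 receptor (Homo sapiens); on this read-out lower numbers stand for stronger inhibition and higher numbers for weaker inhibition. Compound 2 `O=C(c1ccc(N2CCCC2)cc1Cl)N1CCCCc2ccccc21` gives 9 nM in this assay. The step of a 1.5-fold higher number from compound 1 to compound 2 (0.18 log units; within the scatter) is the only measured one in the series, and it leaves the two values indistinguishable within the scatter; compound 2 therefore stands at neither end in any meaningful sense, its number being separated from that of compound 1 by less than the usual scatter.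

Compound 3 `O=C(c1ccc(N2CCCCC2)cc1Cl)N1CCCCc2ccccc21` differs from compound 2 only in piperidin-1-yl in place of pyrrolidin-1-yl on an aromatic carbon. Within the data shown here, no measured step enlarges a saturated ring at this position; the one step available, from compound 1 to compound 2, exchanges an open-chain substituent for a ring at the same aromatic carbon and stays within the scatter. The substituent at this position has so far tolerated that change without a shift beyond the scatter, so the expectation for compound 3 in this assay is a step of a 1.1-fold higher number from compound 2 to compound 3 (0.05 log units; within the scatter) that stays within the scatter, with no direction preferred. Compound 3 is accordingly estimated at 10 nM, with a range from 4 nM to 25 nM.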

Compound 3, half-maximal inhibitory concentration: 120 nM
The estimate for compound 3 lay 12-fold (1.08 log units) below the measured number, outside the stated range (above it).
By their numbers in this assay, from the lowest: compounds 1 and 2 (each within the scatter of the next); then compound 3.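

In this assay this aromatic carbon, para to a large group and meta to a chloro group, proves sensitive to the size of the saturated ring: piperidin-1-yl in place of pyrrolidin-1-yl gives a 13-fold higher number from compound 2 to compound 3 (1.12 log units; beyond the scatter) even though the two groups differ by one ring carbon and have the same donor and acceptor counts. The earlier tolerance therefore does not extend to every cyclic amine, since the allylamino and pyrrolidin-1-yl groups of compound 1 and compound 2 remain within the scatter of each other, whereas piperidin-1-yl gives a 20-fold higher number from compound 1 to compound 3 (1.31 log units; beyond the scatter) and leaves compound 3 the weakest of the three. No available evidence accounts for this loss.

With a single five-membered and a single six-membered ring on hand, these compounds do not show whether the loss follows ring size generally or belongs to piperidin-1-yl alone. An azepan-1-yl group would test the larger ring, while a morpholin-4-yl group would show whether a six-membered ring carrying a ring oxygen behaves like piperidin-1-yl at this position.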